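A few compounds are considered here, and "the series" means these few. Any claim that something is new, unique, unknown or untested is made for them only; others in the source may bear on it.

Compound 1, `CC(O)C1C(=O)NC1OC(=O)/C=C/c1ccccc1`: 1590 nM in a functional assay on MCF7 cells (Homo sapiens) for inhibition, read by MTT assay; on this read-out lower numbers stand for stronger inhibition and higher numbers for weaker inhibition.
Compound 2, `CC(O)C1C(=O)NC1OC(=O)/C=C/c1ccc(N)cc1`: 1590 nM in this assay.

Compound 2 stands level with compound 1, as the step of no change at the digits printed from compound 1 to compound 2 (within the scatter) shows. Compound 3 is `CC(O)C1C(=O)NC1OC(=O)/C=C/c1ccc(Cl)cc1`; the change from compound 2 is chloro in place of amino on an aromatic carbon. Within the data shown here, the only measured step touching the same place on the ring is no change at the digits printed from compound 1 to compound 2 (within the scatter), where amino took the place of hydrogen without effect. A second swap at that spot is therefore expected to leave the reading about where it is, so the expected step of no change at the digits printed from compound 2 to compound 3 (within the scatter) is none beyond the scatter. For compound 3 the estimate in this assay is 1590 nM, with a range from 600 nM to 4200 nM.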

Compound 3, half-maximal inhibitory concentration: 1590 nM
The estimate for compound 3 equals the measured number at the digits printed; the range from low to high includes it.
By their numbers in this assay, from the lowest: compounds 1, 2 and 3 (each within the scatter of the next).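

In this assay, chloro in place of amino gives no change at the digits printed from compound 2 to compound 3 (within the scatter), and chloro in place of hydrogen gives no change at the digits printed from compound 1 to compound 3 (within the scatter). This place on the ring has now held hydrogen, amino and chloro with the same printed reading, even though the hydrogen-bond donor and acceptor counted on amino leave with the swap. No supporting evidence is available to explain this flat result. As far as these compounds go, whether a carboxylic acid or a longer chain at this place would shift the reading stays open. So does whether any group here can move it at all.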